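Swapping 4-chlorophenyl for 3-chlorophenyl on a stable compound

This account rests on a few compounds, and the source may have more. Where it says the series, first, only, none or still open, it means among the compounds named here.

Compound 1 `CCCCCCCCc1ccc(OCC(=O)Cn2nnc(SC)n2)cc1`: < 5%
Compound 2 `CCCCCCCCc1ccc(OCC(=O)Cn2nnc(-c3ccc(Cl)cc3)n2)cc1`: 74%

For the measured compounds named here, in an ADME assay on S9 fraction from liver (Rattus norvegicus) for metabolic stability, read by LC-MS, using NADPH, with a stated time of 30 min (on this read-out higher numbers stand for a more stable compound and lower numbers for a less stable compound), compound 2 gives 74%, the only true number so far. Compound 1 reads < 5%, which is a limit of the assay and not a number. Going by the values given here, the single measured step, a number at least 69 percentage points higher from compound 1 to compound 2 (beyond the scatter), brought 4-chlorophenyl in place of methylsulfanyl. Compound 3 `CCCCCCCCc1ccc(OCC(=O)Cn2nnc(-c3cccc(Cl)c3)n2)cc1` differs by a much smaller change: 3-chlorophenyl in place of 4-chlorophenyl on an aromatic carbon. The chlorophenyl group stays, so a step of that size is not expected in this assay. Compound 3 is estimated at 66%, with a range of 40% to 88%. This estimate means an expected a number 8 percentage points lower from compound 2 to compound 3 (within the scatter).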

Compound 3, percent of the compound remaining: 69%
The estimate for compound 3 lay 3 percentage points below the measured number; measured number inside the range.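

In this assay, the swap gives a number 5 percentage points lower from compound 2 to compound 3 (within the scatter), so on this aromatic carbon of the five-membered ring, the two chlorophenyl groups cannot be told apart. The 3-chlorophenyl group also gives a number at least 64 percentage points higher from compound 1 to compound 3 (beyond the scatter), so the large gain over methylsulfanyl is not confined to 4-chlorophenyl. Compound 1 reads at a limit and not a number, so the exact size of that step stays unknown: the limit of < 5% in this assay, at which 1 of the 3 values shown sits.

The compounds shown leave open whether the chlorine itself is needed. A plain phenyl, or a phenyl carrying an amine or a carboxylic acid in its place, could answer that.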